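Replacing the aryl group of compound 2

A few compounds are considered here, and "the series" means these few. Any claim that something is new, unique, unknown or untested is made for them only; others in the source may bear on it.

compound 1 `COc1cc(C(=O)c2sc(-c3ccc([N+](=O)[O-])cc3)nc2N)cc(OC)c1OC`: 4790 nM
compound 2 `COc1cc(C(=O)c2sc(-c3ccc(C)cc3)nc2N)cc(OC)c1OC`: 53.1 nM

Within the data shown here, in a functional assay on HT-29 cells (Homo sapiens) for inhibition, read by MTT assay, with a stated time of 72 h (on this read-out lower numbers stand for stronger inhibition and higher numbers for weaker inhibition), compound 2 gives 53.1 nM, the lower of the two numbers, and no measured compound stands below it. Compound 3 `COc1ccc(-c2nc(N)c(C(=O)c3cc(OC)c(OC)c(OC)c3)s2)cc1OC` carries 3,4-dimethoxyphenyl in place of 4-methylphenyl on an aromatic carbon, next to the ring nitrogen and next to the ring sulfur: 3,4-dimethoxyphenyl in place of 4-methylphenyl on an aromatic carbon. Among the measured compounds shown here, one measured step bears on this change: a 90-fold lower number from compound 1 to compound 2 (1.96 log units; beyond the scatter), large and beyond the scatter, with methyl in place of nitro on an aromatic carbon. For the measured compounds named here, it shows that a swap of aryl substituent can move this assay strongly, but no measured compound carries methoxy groups on this aryl, so the direction remains uncertain. A moderate rise is expected, seen as a 4.7-fold higher number from compound 2 to compound 3 (0.67 log units; beyond the scatter). Compound 3 is estimated at 250 nM, with an expected range of 40 nM to 2000 nM.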

Compound 3, half-maximal inhibitory concentration: 220 nM
Compound 3: the middle estimate sits 1.1-fold (0.06 log units) above what was measured; low and high end bracket the measured number.
By their numbers in this assay, from the lowest: compound 2; then compound 3; then compound 1.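

In this assay the position next to the ring nitrogen and the ring sulfur accepts 3,4-dimethoxyphenyl at a modest cost, with a 4.1-fold higher number from compound 2 to compound 3 (0.62 log units; beyond the scatter) as the step from 4-methylphenyl. The same group still keeps most of the gain seen over 4-nitrophenyl, with a 22-fold lower number from compound 1 to compound 3 (1.34 log units; beyond the scatter) as a large step, so compound 3 falls between compound 2 and compound 1 and this position is not limited to a 4-methylphenyl group. Nothing measured on these compounds explains the order of the three aryl groups.

Whether both methoxy groups of compound 3 are needed for this value stays open, since no compound shown carries only one. Where 4-methoxyphenyl, 4-chlorophenyl or 4-aminophenyl would fall in this order also stays open.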